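A few compounds are considered here, and "the series" means these few. Any claim that something is new, unique, unknown or untested is made for them only; others in the source may bear on it.

Three compounds share one core and differ only in the group on an amide-type nitrogen. Compound 1, `Cc1nc(N)sc1CCCN/C(N)=N/C(=O)NC(C)c1ccc(Br)cc1`, gives 55 nM in a functional assay on Right cardiac atrium for agonist activity at histamine H2 receptor (Cavia porcellus), with a stated time of 30 min, in the presence of a further agent that is not named here; a higher number here means that more compound is needed for the effect, a lower number that less compound is needed. Compound 2, `Cc1nc(N)sc1CCCN/C(N)=N/C(=O)N[C@@H](C)c1ccccc1`, gives 23.4 nM in this assay. Compound 3, `CCCCCCNC(=O)/N=C(\N)NCCCc1sc(N)nc1C`, gives 15.9 nM in this assay, the lowest of the three numbers, while the measured step of a 1.5-fold lower number from compound 2 to compound 3 (0.17 log units; within the scatter) falls within the scatter. Compound 4 is `Cc1nc(N)sc1CCCN/C(N)=N/C(=O)NC(C)c1cccs1`, with the change (1-(thiophen-2-yl)ethyl in place of hexyl on an amide-type nitrogen). Within the data shown here, the one measured step that bears on it is a 1.5-fold lower number from compound 2 to compound 3 (0.17 log units; within the scatter), which shows that swapping a ring-bearing ethyl group for hexyl barely moved the number. Compound 4 is therefore expected to show a 1.6-fold higher number from compound 3 to compound 4 (0.20 log units; within the scatter), no shift beyond the scatter. The estimate for compound 4 is 25 nM, with a range from 10 nM to 70 nM.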

Compound 4, half-maximal effective concentration: 10 nM
Compound 4: middle estimate off by 2.5-fold (0.40 log units), on the high side; measured number inside the range.
By their numbers in this assay, from the lowest: compounds 4, 3 and 2 (each within the scatter of the next, the first and the last beyond it); then compound 1.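

Replacing the open hexyl chain with a group carrying a five-membered aromatic ring leaves the result in the same range, with a 1.6-fold lower number from compound 3 to compound 4 (0.20 log units; within the scatter). Among these compounds, what the earlier compounds did not show is that the ring on this chain carbon matters: thiophen-2-yl in place of phenyl gives a 2.3-fold lower number from compound 2 to compound 4 (0.37 log units; beyond the scatter), and thiophen-2-yl in place of 4-bromophenyl gives a 5.5-fold lower number from compound 1 to compound 4 (0.74 log units; beyond the scatter). Both steps are modest.

Nothing available explains these steps. Going by these compounds, whether a pyridine ring or a chain longer than hexyl in this place would keep the number this low remains open.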